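The compounds below may be only part of what the source reports. "The series", "measured", "known", "first", "only" and "open" are said of these compounds alone.

Compound 2 `Nc1cccc(-c2cn3nc(Cc4ccccc4)sc3n2)c1` gives 7400 nM in a functional assay on L1210 cells (Mus musculus) for inhibition, read by cell counting, with a stated time of 2 days (a higher number here means a weaker inhibitor, a lower number a stronger inhibitor), the lowest of the three numbers recorded: compound 3 `COc1cccc(Cc2nn3cc(-c4cccc(N)c4)nc3s2)c1` gives 21000 nM, and compound 1 `Nc1cccc(-c2cn3nc(CCc4ccccc4)sc3n2)c1` gives 31000 nM. Compound 4 `Nc1cccc(-c2cn3nc(-c4ccc(F)cc4)sc3n2)c1` differs from compound 2 by 4-fluorophenyl in place of benzyl on an aromatic carbon. Two recorded steps bear on this change. Shortening the chain at the same place gave a 4.2-fold lower number from compound 1 to compound 2 (0.62 log units; beyond the scatter), while a methoxy on the ring gave a 2.8-fold higher number from compound 2 to compound 3 (0.45 log units; beyond the scatter); the step of a 1.5-fold lower number from compound 1 to compound 3 (0.17 log units; within the scatter) lay within the scatter. Among the compounds with values here, no recorded step removes the saturated carbon altogether or introduces fluorine, so the direction is uncertain; a step of the size seen from compound 1 to compound 2 is not expected, and compound 4 is estimated at 5000 nM, between 1500 nM and 16000 nM, meaning a 1.5-fold lower number from compound 2 to compound 4 (0.17 log units; within the scatter).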

Compound 4, half-maximal inhibitory concentration: >= 250000 nM
Compound 4: a limit, no number (the forecaster's own chance of this, stated with the estimate: 5%); middle value at least 50-fold (1.69 log units) from the limit.
By their numbers in this assay, from the lowest: compound 2; then compounds 3 and 1 (each within the scatter of the next). At a limit, above all of these: compound 4.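

Within the data shown here, putting 4-fluorophenyl in place of benzyl on this aromatic carbon gave an at least 33-fold higher number from compound 2 to compound 4 (1.52 log units; beyond the scatter), a far larger step than any among the earlier compounds, all of which keep a saturated chain carbon here. For compound 4 the result is a limit, not a number: the limit of >= 250000 nM in this assay, at which 1 of the 4 values shown sits.

The change removes the saturated carbon and brings in fluorine together, and the compounds shown do not separate the two. Also open, from the compounds shown here alone, is how a plain phenyl on this aromatic carbon, or an amine on the benzyl ring, would stand.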